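The compounds below may be only part of what the source reports. "The series", "measured", "known", "first", "only" and "open" are said of these compounds alone.

Working notes on the series.

The shared core is carried by compound 1 `COc1cc(Cl)cc(-c2nn(-c3cccc(NC(=O)c4cccc(C(F)(F)F)c4)c3)cc2-c2ccncc2)c1` and compound 2 `O=C(Nc1cccc(-n2cc(-c3ccncc3)c(-c3cc(O)cc(Cl)c3)n2)c1)c1cc(C(F)(F)F)cc(C(F)(F)F)c1`, which differ from each other in two places, so only their two numbers can be set side by side. In a functional assay on SF-268 cells (Homo sapiens) for inhibition, read by sulforhodamine B assay, with a stated time of 48 h, tested at 10 uM (a lower number here means a stronger effect, a higher number a weaker effect of the compound at the concentration tested), compound 1 gives 77.3%. In this assay compound 2 gives 69.4%, a number that sits apart from compound 1 by an amount within the scatter, so the two cannot be ranked against each other on these data.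

The step under review leads from compound 2 to compound 3 `COc1cc(Cl)cc(-c2nn(-c3cccc(NC(=O)c4cc(C(F)(F)F)cc(C(F)(F)F)c4)c3)cc2-c2ccncc2)c1`. The change is methyl in place of hydrogen on an oxygen on an aromatic ring; it touches only the oxygen on the 3-chloro-5-hydroxyphenyl group, the rest of the molecule being kept. Going by the values given here, no measured pair in the set shows this same change in isolation, so its size is not known from the data at hand. Compound 1 carries the methoxy form already, and its number stands within the scatter of compound 2, which is the only hint available. For compound 3 the expected step in this assay is a number 4.6 percentage points higher from compound 2 to compound 3 (within the scatter), that is, no change beyond the scatter. The estimate for compound 3 in this assay is 74%, with a range from 60% to 88%.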

Compound 3, a percentage reported as activity, at one concentration (the size of the read-out at that concentration, not a potency): 89.2%
For compound 3 the middle estimate is 15.2 percentage points below the measured one; measured number above the stated range.
By their numbers in this assay, from the lowest: compounds 2 and 1 (each within the scatter of the next); then compound 3.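

In this assay the hydroxy to methoxy change on the 3-chloro-5-hydroxyphenyl group can now be read on its own, as a number 19.8 percentage points higher from compound 2 to compound 3 (beyond the scatter); with the rest of the molecule kept, the hydroxy form therefore gives the stronger effect at the concentration tested. The earlier pair differed in two places and could not show this. The second reading, trifluoromethyl in place of hydrogen on an aromatic carbon, is a number 11.9 percentage points higher from compound 1 to compound 3 (beyond the scatter), so with the methoxy form held fixed this added group also goes with a weaker effect, and compound 3 stands as the weakest of the three, though each modest step rests on a single pair.

Nothing in hand bears on why the number moves with either change.

The compounds shown leave open whether the hydroxy to methoxy step keeps its size when the single trifluoromethyl of compound 1 is present. They also leave open how this oxygen position responds to an ethoxy group or a longer chain on the oxygen, or to an amine in place of the hydroxy group.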